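Hindlimb inhibition in mice: a para-substituent series

The compounds below may be only part of what the source reports. "The series", "measured", "known", "first", "only" and "open" are said of these compounds alone.

Measured compounds:
compound 1 `CC1(C)CC12NC(=O)N(NC(=O)c1ccccc1)C2=O`, 300 mg/kg
compound 2 `Cc1ccc(C(=O)NN2C(=O)NC3(CC3(C)C)C2=O)cc1`, 100 mg/kg

The read-out throughout is a functional assay on the whole organism (Hindlimb) for inhibition, with Mus musculus as the target, with a stated time of 0.5 h; on this read-out higher numbers stand for an effect only at larger amounts of compound and lower numbers for an effect already at smaller amounts. For the measured compounds named here, compound 2 `Cc1ccc(C(=O)NN2C(=O)NC3(CC3(C)C)C2=O)cc1` gives the lowest number of the two measured, with compound 1 `CC1(C)CC12NC(=O)N(NC(=O)c1ccccc1)C2=O` at 300 mg/kg as its only neighbour; the step of a 3.0-fold lower number from compound 1 to compound 2 (0.48 log units; beyond the scatter) is called modest. Compound 3 `CC(C)(C)c1ccc(C(=O)NN2C(=O)NC3(CC3(C)C)C2=O)cc1` has not yet been measured. It differs from compound 2 by tert-butyl in place of methyl on an aromatic carbon. Going by the values given here, the one measured step that bears on this change is a 3.0-fold lower number from compound 1 to compound 2 (0.48 log units; beyond the scatter), where adding the methyl to the aromatic carbon lowered the number beyond the scatter. Whether a larger group at the same place moves the number further is not shown by any measured pair. Compound 3 is therefore expected to stand close to compound 2 in this assay, with the estimated step of no change at the digits printed from compound 2 to compound 3 (within the scatter) lying within or just beyond the scatter. The estimate for compound 3 is 100 mg/kg, with a range from 30 mg/kg to 300 mg/kg.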

Compound 3, minimum effective dose: 30 mg/kg
The estimate for compound 3 lay 3.3-fold (0.52 log units) above the measured number, within the range that was stated.
By their numbers in this assay, from the lowest: compound 3; then compound 2; then compound 1.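

In this assay, the change did not stop at methyl: tert-butyl in place of methyl on the aromatic carbon gave a 3.3-fold lower number from compound 2 to compound 3 (0.52 log units; beyond the scatter), a second step beyond the scatter at the same place. Measured against hydrogen at that carbon, tert-butyl gave a 10-fold lower number from compound 1 to compound 3 (1.00 log units; beyond the scatter), so the three compounds fall in the order hydrogen, methyl, tert-butyl, and none of them goes against that order. Nothing available explains why the number falls along this series.

On these data alone, the three compounds carry only hydrogen or all-carbon groups at this place, so it remains open whether a chlorine atom, a methoxy group or a carboxylic acid on the same aromatic carbon would fit this order. As far as these compounds go, it also remains open whether a group larger than tert-butyl, such as a phenyl ring, would lower the number further or reverse the trend.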